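This account rests on a few compounds, and the source may have more. Where it says the series, first, only, none or still open, it means among the compounds named here.

Of the compounds shown here, three have so far been tested in a functional assay on A549 cells (Homo sapiens) for inhibition, read by sulforhodamine B assay, with a stated time of 48 h, tested at 10 uM; a lower number here means less inhibition of growth, a higher number more inhibition of growth at the concentration tested. Compound 1 (`COc1ccc(-c2nc3sc(-c4ccccc4)cn3n2)cc1`) gives 49%, compound 2 (`C/C(=N/O)c1ccc(NC(=O)Cn2nc(C(F)(F)F)nc2N)cc1`) gives 29%, and compound 3 (`COc1cc(-c2nc(N)n(CC(=O)Nc3ccc(/C(C)=N\O)cc3)n2)cc(OC)c1OC`) gives 25.8%. Compound 2 and compound 3 lie within the usual scatter of each other, so these two numbers cannot be told apart. Compound 1 stands higher than compound 2 by a gap beyond the scatter.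

The next compound to consider is compound 4 (`C/C(=N/O)c1ccc(NC(=O)Cn2nc(-c3ccccc3)nc2N)cc1`), which differs from compound 2 in one place. It has phenyl in place of trifluoromethyl on an aromatic carbon, a change counted as phenyl in place of trifluoromethyl on an aromatic carbon. That carbon is part of a five-membered aromatic ring with 3 nitrogen.

Within the data shown here, no pair of measured compounds differs in one place, so the data offer no direct guide to the effect of this swap. The starting expectation is therefore no change beyond the scatter, in either direction. The expected size of the move is a number 1 percentage points lower from compound 2 to compound 4 (within the scatter), an estimate that amounts to almost no change. The range must stay wide, since a single-concentration reading of this kind can move in either direction. For compound 4 the estimated value in this assay is 28%, with an expected range from 14% to 43%.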

Compound 4, percent growth inhibition at one concentration: 32%
Beside the measured number, compound 4's estimate is 4 percentage points below it, and the stated range covers the measured number.
By their numbers in this assay, from the lowest: compounds 3, 2 and 4 (each within the scatter of the next); then compound 1.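

In this assay, among these compounds, putting phenyl in place of trifluoromethyl on this aromatic carbon gives a number 3 percentage points higher from compound 2 to compound 4 (within the scatter) and so provides the first direct reading of a change at this position. A group with no ring and a six-membered aromatic ring of carbon only, both on the carbon between two ring nitrogen atoms, give readings that cannot be told apart at the single concentration tested, so this one swap does not show the position to be sensitive to the change. Nothing measured here accounts for the lack of a clear shift in growth inhibition.

On these data alone, whether other groups on this carbon, such as a carboxylic acid, a methyl group or a longer carbon chain, would move the reading beyond the usual scatter remains open, since a single swap cannot show how far this tolerance extends. Compound 1, at 49%, differs from compound 2 and compound 4 in more than one place, so the compounds shown do not reveal which part of its structure sets its number apart.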